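The source may report more compounds than this note shows. Statements on the series, on what has been measured and on what is new or still open speak of the compounds shown alone.

Compound 2, `CCOC(=O)c1c(-c2cccc(-c3ccccc3)c2)[nH]c2cc(OC)ccc2c1=O`, is the point of departure. In an ADME assay on Raji cells (Homo sapiens) for cytotoxicity, read by luminescence, with a stated time of 72 h (on this read-out higher numbers stand for an effect only at larger amounts of compound and lower numbers for an effect already at smaller amounts), compound 2 gives > 21500 nM, which is a limit of the assay and not a number. Compound 1, `C=Cc1cccc(-c2[nH]c3cc(OC)ccc3c(=O)c2C(=O)OCC)c1`, gives > 21500 nM in this assay, again a limit. Compound 3, `CCOC(=O)c1c(-c2cccc(Oc3ccccc3)c2)[nH]c2cc(OC)ccc2c1=O`, gives > 21500 nM in this assay, likewise a limit. The three steps that join them, a step that the two limits leave unreadable from compound 1 to compound 2, a step that the two limits leave unreadable from compound 1 to compound 3 and a step that the two limits leave unreadable from compound 2 to compound 3, cannot be read in size because of the limit of > 21500 nM in this assay, at which 3 of the 3 values shown sit. The compound still to be measured is compound 4, `CCOC(=O)c1c(-c2cccc(Cl)c2)[nH]c2cc(OC)ccc2c1=O`. Its change from compound 2 is chloro in place of phenyl on an aromatic carbon. Among the compounds with values here, none of the measured steps offers a readable size, so the expectation rests only on the three limits. Compound 4 is expected to sit at 30000 nM, with a range from 15000 nM to 80000 nM, and most likely it will again be reported as a limit. The step that the limit leaves unreadable from compound 2 to compound 4 is therefore estimated to be none beyond the scatter.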

Compound 4, half-maximal effective concentration in the Raji assay: > 21500 nM
Compound 4: no number, only a limit; the forecaster's own chance of this, stated with the estimate: 80%; the middle value lies beyond the limit too.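

In the Raji assay compound 4 gives > 21500 nM, a limit of the assay and not a number. Its steps to compound 1, compound 2 and compound 3 in the Raji assay cannot be read. In a physicochemical assay for solubility, at pH 7.4 (on this read-out higher numbers stand for higher solubility and lower numbers for lower solubility), compound 2 gives 200 nM and compound 4 gives 58000 nM. In the physicochemical assay chloro in place of phenyl on an aromatic carbon is a 290-fold higher number from compound 2 to compound 4 (2.46 log units; beyond the scatter). The compounds shown leave open at what amount any of these four would have an effect in the Raji assay: the limit of > 21500 nM in the Raji assay, at which 4 of the 4 values shown sit.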